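Hydroxyphenyl imine on the cyclohexene-fused core: cytotoxicity outlook

The source may report more compounds than this note shows. Statements on the series, on what has been measured and on what is new or still open speak of the compounds shown alone.

Compound 3 `Clc1ccc(/C=N/c2sc3c(c2-c2nc4ccccc4s2)CCCC3)cc1` gives 397 ug/mL in an ADME assay on HepG2 cells (Homo sapiens) for cytotoxicity, read by MTT assay, with a stated time of 72 h; a higher number here means that more compound is tolerated, a lower number that less compound is tolerated. Its number sits within the scatter of compound 1 `Fc1ccccc1/C=N/c1sc2c(c1-c1nc3ccccc3s1)CCC2` at 394 ug/mL and of compound 2 `C(=C/c1ccccc1)\C=N\c1sc2c(c1-c1nc3ccccc3s1)CCC2` at 215 ug/mL; no ordering among the three is supported. Compound 4 `Oc1ccccc1/C=N/c1sc2c(c1-c1nc3ccccc3s1)CCCC2` keeps the core of compound 3 and differs only in the group on the imine carbon: 2-hydroxyphenyl in place of 4-chlorophenyl on a carbon with a double bond to nitrogen. Going by the values given here, the one measured step at that position, a 1.8-fold lower number from compound 1 to compound 2 (0.26 log units; within the scatter), stayed within the scatter, and no measured step introduces a hydroxyl. Compound 4 is therefore expected to show no shift beyond the scatter, a 1.0-fold lower number from compound 3 to compound 4 (0.02 log units; within the scatter). The estimate for compound 4 in this assay is 380 ug/mL, with a range from 190 ug/mL to 760 ug/mL.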

Compound 4, half-maximal cytotoxic concentration: 114 ug/mL
Compound 4: middle estimate off by 3.3-fold (0.52 log units), on the high side; measured number below the stated range.
By their numbers in this assay, from the lowest: compounds 4, 2, 1 and 3 (each within the scatter of the next, the first and the last beyond it).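

The group on the carbon with a double bond to nitrogen can move the number in this assay: 2-hydroxyphenyl in place of 4-chlorophenyl gives a step beyond the scatter (a 3.5-fold lower number from compound 3 to compound 4 (0.54 log units; beyond the scatter)), unlike the earlier step at this position (a 1.8-fold lower number from compound 1 to compound 2 (0.26 log units; within the scatter)). The exchange swaps chlorine for oxygen at an equal heavy-atom count and adds a hydrogen-bond donor and acceptor. No available measurement accounts for the drop.

Going by these compounds, whether the step follows the hydroxyl or the loss of chlorine remains open. Also open, on these data alone, is how a methoxy group or an amine on that phenyl ring would read, and whether the same exchange behaves alike on the core of compound 1.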